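The source may report more compounds than this note shows. Statements on the series, on what has been measured and on what is new or still open speak of the compounds shown alone.

Measured so far in a functional assay on B16-F10 cells (Mus musculus) for antiproliferative activity, read by ELISA and MTT assay, with a stated time of 48 h; on this read-out lower numbers stand for stronger inhibition and higher numbers for weaker inhibition:
compound 1 `O=C(/C=C/c1ccccc1)NS(=O)(=O)c1ccccc1` — 3.5 ug/mL
compound 2 `Cc1ccc(S(=O)(=O)NC(=O)/C=C/c2ccccc2)cc1` — 13.8 ug/mL
compound 3 `O=C(/C=C/c1ccccc1)NS(=O)(=O)c1ccc(Cl)cc1` — 2.2 ug/mL

Compound 3 holds the lowest number of the three. The step of a 1.6-fold lower number from compound 1 to compound 3 (0.20 log units; within the scatter) is within the scatter, so the two cannot be ordered; the step of a 6.3-fold lower number from compound 2 to compound 3 (0.80 log units; beyond the scatter) is beyond it. The other step, a 3.9-fold higher number from compound 1 to compound 2 (0.60 log units; beyond the scatter), is likewise beyond the scatter. All three steps sit on the ring carrying the sulfonyl group.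

Compound 4 `CN(C)c1ccc(/C=C/C(=O)NS(=O)(=O)c2ccc(Cl)cc2)cc1` is not yet measured. It differs from compound 3 in one place: dimethylamino in place of hydrogen on an aromatic carbon. Going by the values given here, this change sits on the other ring, the one bearing the double bond, and none of the measured steps touches that ring. Among the compounds with values here, there is therefore no measured step that bears directly on it; the sulfonyl-ring steps show that a single substituent on a ring can shift the number by a modest amount in either direction, but they give no direction for this ring. The working expectation is a step of no more than modest size and of uncertain sign, most likely within the scatter, so compound 4 is estimated at 2.5 ug/mL, with a range from 0.8 ug/mL to 8 ug/mL, which corresponds to an expected step of a 1.1-fold higher number from compound 3 to compound 4 (0.06 log units; within the scatter).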

Compound 4, half-maximal inhibitory concentration: 2.8 ug/mL
For compound 4 the middle estimate is 1.1-fold (0.05 log units) below the measured one, and the stated range covers the measured number.
By their numbers in this assay, from the lowest: compounds 3, 4 and 1 (each within the scatter of the next); then compound 2.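

In this assay, going by these compounds alone, dimethylamino in place of hydrogen gives the first reading for the ring bearing the double bond: a 1.3-fold higher number from compound 3 to compound 4 (0.10 log units; within the scatter), so compound 3 and compound 4 cannot be ordered. On the chloro-bearing scaffold of compound 3, this aromatic carbon, para to a large group, therefore takes a substituent of 3 heavy atoms with no change that can be read, whereas on the ring carrying the sulfonyl group, methyl in place of hydrogen gave a 3.9-fold higher number from compound 1 to compound 2 (0.60 log units; beyond the scatter) and lay beyond the scatter. That contrast covers only these two single changes and does not establish a general difference between the rings, and no measurement is available that accounts for the result.

Going by these compounds, it remains open whether this flat result is particular to dimethylamino or extends to other groups at the same place, such as a methoxy group, a primary amine or a carboxylic acid. On these data alone, it is also open whether dimethylamino gives the same result when the chloro on the other ring is replaced by hydrogen or methyl.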